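The source may hold more compounds than are shown below. What is called first, only, known or untested is meant among the compounds shown, and "the series" means these compounds.

Of the compounds shown here, three have already been tested for how much they harm human liver-derived cells, and a fourth waits for its turn. Compound 1 `O=C(NC(=S)n1ccc2c(OCCCCCOc3ccc(Cl)cc3)cccc21)c1ccccc1` carries a benzoyl group on the thiourea nitrogen and a long five-carbon chain to a chlorophenyl ether; in an ADME assay on Huh-7 cells (Homo sapiens) for cytotoxicity (on this read-out lower numbers stand for higher toxicity in this test and higher numbers for lower toxicity in this test), compound 1 gives 29500 nM. Compound 2 `O=C(NC(=S)N1CCc2cccc(OCc3ccccc3)c21)c1ccccc1` has a shorter benzyl ether on the shared core, and in this assay compound 2 gives > 50000 nM, which is a limit of the measurement and not a number. Compound 3 `Cc1ccc(C(=O)NC(=S)N2CCc3c(OCCCCCOc4ccc(Cl)cc4)cccc32)cc1` keeps the long chloro-phenoxy chain of compound 1 but carries a (4-methylphenyl)carbonyl group; in this assay compound 3 gives > 50000 nM, again a limit rather than a number. So compound 3 stands at the edge of what the test can report, together with compound 2, at the limit of > 50000 nM in this assay, at which 2 of the 3 values shown sit.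

Compound 4 `O=S(=O)(NC(=S)N1CCc2c(OCCCCCOc3ccc(Cl)cc3)cccc21)c1ccccc1` differs from compound 3 in one place: phenylsulfonyl in place of (4-methylphenyl)carbonyl on an amide-type nitrogen. For the measured compounds named here, no measured pair shows this change, so the expected step can only be guessed. The step from compound 3 to compound 4 is expected to stay within the usual scatter, a number no higher from compound 3 to compound 4 (the limit leaves the size open). For compound 4 in this assay the expected value is 50000 nM, somewhere between 20000 nM and 100000 nM.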

Compound 4, half-maximal cytotoxic concentration: > 50000 nM
Compound 4 ended at the assay's limit; the forecaster's own chance of this, stated with the estimate: 55%; the middle value lies on the limit itself.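

In this assay the step from compound 3 to compound 4 cannot be read, because both compounds give a limit and not a number: the limit of > 50000 nM in this assay, at which 3 of the 4 values shown sit.

The compounds shown leave open whether phenylsulfonyl in place of (4-methylphenyl)carbonyl on the amide-type nitrogen changes the toxicity of compound 4 in this test at all.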